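From Nitrile to Difluorophenyl: A Solubility Step

A few compounds are considered here, and "the series" means these few. Any claim that something is new, unique, unknown or untested is made for them only; others in the source may bear on it.

Compound 1 `Cc1cc(OCc2ccccn2)n2nc(C)c(-c3ccccc3)c2n1` gives 25600 nM in a physicochemical assay for solubility, read by HPLC, using the shake flask method, measured as kinetic solubility, with a stated time of 2 h, at pH 7.4; a higher number here means a more soluble compound, a lower number a less soluble compound. Compound 2 `Cc1cc(NCc2ccccn2)n2ncc(-c3ccc(C#N)cc3)c2n1` reaches only a limit of this assay, < 5000 nM, and so no number is known for it; it sits at the limit of < 5000 nM in this assay, at which 1 of the 2 values shown sits. Compound 3 `Cc1cc(NCc2ccccn2)n2ncc(-c3ccc(F)cc3F)c2n1` carries 2,4-difluorophenyl in place of 4-cyanophenyl on an aromatic carbon. No measured step of this kind is shown among the compounds here. The change from compound 2 to compound 3 is expected to stay within the scatter, as a step that the limit leaves unreadable from compound 2 to compound 3. Compound 3 is thus expected to give about 3000 nM, between 700 nM and 9000 nM, most likely again as a limit rather than a number.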

Compound 3, solubility: < 5000 nM
Compound 3 gave a limit, no number; the forecaster's own chance of this, stated with the estimate: 70%; the middle value lies beyond the limit too.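

Compound 2 and compound 3 both give only a limit in this assay, and no step can be read between them: the limit of < 5000 nM in this assay, at which 2 of the 3 values shown sit.

As far as these compounds go, what 2,4-difluorophenyl in place of 4-cyanophenyl does to the actual solubility of these two compounds stays open.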